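A few compounds are considered here, and "the series" means these few. Any claim that something is new, unique, unknown or untested is made for them only; others in the source may bear on it.

The measured compounds, all tested in a functional assay on MCF7 cells (Homo sapiens) for cytotoxicity, read by MTT assay, with a stated time of 48 h; a lower number here means a stronger inhibitor, a higher number a weaker inhibitor:

Compound 1, `CC(=NNC(=S)Nc1ccccc1F)c1ccccn1`: 0.39 nM
Compound 2, `CC(=NNC(=S)Nc1ccccc1[N+](=O)[O-])c1ccccn1`: 5.7 nM
Compound 3, `CC(=NNC(=S)Nc1ccc(F)cc1)c1ccccn1`: 1.2 nM

Compound 4, `CC(=NNC(=S)Nc1ccc([N+](=O)[O-])cc1)c1ccccn1`, has not yet been measured in this assay.

Compound 1 and compound 2 share a core and differ in one place: nitro in place of fluoro on an aromatic carbon. That change went with a 15-fold higher number from compound 1 to compound 2 (1.16 log units; beyond the scatter), a large weakening. Compound 3 has the same atoms as compound 1, joined differently; the difference between the two cores is not broken down here. Compound 3 sits between the other two in this assay, with a number beyond the scatter from each of them.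

From compound 3 to compound 4 the same kind of change is made: nitro in place of fluoro on an aromatic carbon. The surroundings are not identical, since in compound 2 the nitro sits ortho to a large group, while in compound 4 it sits para to a large group. For the measured compounds named here, still, the one measured example is the best guide. Because a 15-fold higher number from compound 1 to compound 2 (1.16 log units; beyond the scatter) was large, a step of similar size is expected here, a 12-fold higher number from compound 3 to compound 4 (1.07 log units; beyond the scatter), with room for it to be somewhat smaller. Compound 4 is therefore estimated at 14 nM, likely between 4 nM and 50 nM.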

Compound 4, half-maximal inhibitory concentration: 52 nM
Beside the measured number, compound 4's estimate is 3.7-fold (0.57 log units) below it; the measured number lies above the stated range.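

In this assay, nitro in place of fluoro again went with a weaker compound, with a 43-fold higher number from compound 3 to compound 4 (1.64 log units; beyond the scatter), so the direction of the change carried over from one core to the other. The size of the step did not carry over exactly, and the gap between the two steps is larger than repeated measurements would be expected to produce: the same change on two cores in this assay, a 15-fold higher number (1.16 log units; beyond the scatter) from compound 1 to compound 2 and a 43-fold higher number (1.64 log units; beyond the scatter) from compound 3 to compound 4, 3.0-fold (0.47 log units) apart, beyond the scatter of two such steps. Within these two pairs, then, the change is large each time, but one step cannot simply be copied onto another core as a fixed amount, and two pairs can neither explain the gap nor give a rule for further cores.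

The compounds shown carry only fluoro or nitro on the aromatic ring, so it stays open how an amine, a methoxy group or a carboxylic acid in the same places would compare. On these data alone, it also stays open whether the same steps would appear in cells other than those tested here.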